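Cytotoxicity notes: swapping the aryl on the ring nitrogen

This account rests on a few compounds, and the source may have more. Where it says the series, first, only, none or still open, it means among the compounds named here.

Measured so far:
compound 1 `Cc1ccccc1-c1nn(-c2ccc(Cl)cc2)cc1CNCCN1CCN(C)CC1` — 17000 nM
compound 2 `Cc1ccccc1-c1nn(-c2cc(F)ccc2F)cc1CNCCN1CCN(C)CC1` — a limit of the assay, > 20000 nM
compound 3 `Cc1ccccc1-c1nn(-c2ccc(F)cc2)cc1CNCCN1CCN(C)CC1` — a limit of the assay, > 20000 nM

In an ADME assay on Huh-7 cells (Homo sapiens) for cytotoxicity (a lower number here means that less compound is tolerated, a higher number that more compound is tolerated), compound 1 gives 17000 nM. Compound 3 stands at a limit of the assay, > 20000 nM, the same limit at which compound 2 also sits (the limit of > 20000 nM in this assay, at which 2 of the 3 values shown sit). Accordingly an at least 1.1-fold higher number from compound 1 to compound 3 (0.07 log units; that floor lies within the scatter) and a step that the two limits leave unreadable from compound 2 to compound 3.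

Compound 4 `Cc1ccc(-n2cc(CNCCN3CCN(C)CC3)c(-c3ccccc3C)n2)c(C)c1` differs from compound 3 by 2,4-dimethylphenyl in place of 4-fluorophenyl on an aromatic nitrogen. Among the compounds with values here, no measured step exchanges a halophenyl for a dimethylphenyl. The aryl changes seen so far, an at least 1.1-fold higher number from compound 1 to compound 2 (0.07 log units; that floor lies within the scatter) and an at least 1.1-fold higher number from compound 1 to compound 3 (0.07 log units; that floor lies within the scatter), stayed within the scatter, so in this assay no step beyond the scatter is expected: a number no higher from compound 3 to compound 4 (the limit leaves the size open). Compound 4 is therefore estimated at 20000 nM, between 9000 nM and 40000 nM.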

Compound 4, half-maximal cytotoxic concentration: > 20000 nM
Compound 4 gave a limit, no number; the forecaster's own chance of this, stated with the estimate: 55%; the middle value lies on the limit itself.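

The aryl on the ring nitrogen need not carry a halogen for a compound to reach the limit of this assay: compound 4, with 2,4-dimethylphenyl, gives a limit and no number, which adds to the following: the limit of > 20000 nM in this assay, at which 3 of the 4 values shown sit.

Only an at least 1.1-fold higher number from compound 1 to compound 4 (0.07 log units; that floor lies within the scatter) can be read, and the steps from compound 2 and from compound 3 to compound 4 cannot.

From the compounds shown here alone, how far compound 2, compound 3 and compound 4 lie past the limit stays open. So does whether an aminophenyl or a carboxyphenyl group on this nitrogen would give a readable number in this assay and a clear step from compound 4.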